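The source may hold more compounds than are shown below. What is called first, only, known or untested is meant among the compounds shown, and "the series" means these compounds.

Compound 1 `COC(=O)N(CCO)c1c(N)nc(-c2nn(Cc3ccccc3F)c3ncccc23)nc1N` gives 0.3 uM in an assay on cells for activation of Guanylate cyclase soluble subunit alpha-1 (Rattus norvegicus), read by cGMP accumulation and immunoassay, with a stated time of 10 min (a higher number here means that more compound is needed for the effect, a lower number that less compound is needed), the second highest of the three numbers measured. Compound 2 `COC(=O)N(Cc1ccccc1F)c1c(N)nc(-c2nn(Cc3ccccc3F)c3ncccc23)nc1N` gives 0.1 uM, and compound 3 `COC(=O)N(Cc1ccc(F)cc1)c1c(N)nc(-c2nn(Cc3ccccc3F)c3ncccc23)nc1N` gives 0.7 uM. The steps seen so far are a 3.0-fold lower number from compound 1 to compound 2 (0.48 log units; beyond the scatter), a 2.3-fold higher number from compound 1 to compound 3 (0.37 log units; beyond the scatter) and a 7.0-fold higher number from compound 2 to compound 3 (0.85 log units; beyond the scatter), each modest. Compound 4 `CC(C)OC(=O)Nc1c(N)nc(-c2nn(Cc3ccccc3F)c3ncccc23)nc1N` differs from compound 1 by (isopropoxycarbonyl)amino in place of (2-hydroxyethyl)(methoxycarbonyl)amino on an aromatic carbon. The measured steps all alter what sits on the saturated chain carbon bound to the amide-type nitrogen; none removes the (2-hydroxyethyl)(methoxycarbonyl)amino group as this change does, so they bear only loosely on it. A modest shift in either direction, or none beyond the scatter, is therefore expected for compound 4, as no change at the digits printed from compound 1 to compound 4 (within the scatter). The estimate for compound 4 is 0.3 uM, with a range from 0.1 uM to 1 uM.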

Compound 4, minimum effective concentration: 0.8 uM
Estimate against measurement, compound 4: 2.7-fold (0.43 log units) below, and the stated range covers the measured number.
By their numbers in this assay, from the lowest: compound 2; then compound 1; then compounds 3 and 4 (each within the scatter of the next).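

In this assay, the step to (isopropoxycarbonyl)amino gives a 2.7-fold higher number from compound 1 to compound 4 (0.43 log units; beyond the scatter), so compound 4 shows that the effect survives with no chain on the amide-type nitrogen. Unlike the earlier steps, this one alters the ester part and removes the 2-hydroxyethyl chain at once, so the two alterations cannot be told apart. Nothing at hand gives a reason for this shift. Still open, on these data alone, is which alteration carries the step, and how a plain (methoxycarbonyl)amino group or a 2-aminoethyl chain on that nitrogen would read.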